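A few compounds are considered here, and "the series" means these few. Any claim that something is new, unique, unknown or untested is made for them only; others in the source may bear on it.

In a functional assay on HCT-116 cells (Homo sapiens) for inhibition, read by colorimetric assay, with a stated time of 3 days (on this read-out lower numbers stand for stronger inhibition and higher numbers for weaker inhibition), compound 1 (`COc1ccc(NC(=O)CCCCCCNC(=O)C(O)(O)C(F)(F)F)cc1`) gives 4520 nM and compound 2 (`CC(=O)c1ccc(NC(=O)CCCCCCNC(=O)C(O)(O)C(F)(F)F)cc1`) gives 12100 nM as the higher of the two numbers, which makes compound 2 the weaker inhibitor of this pair. Compound 3 (`O=C(CCCCCCNC(=O)C(O)(O)C(F)(F)F)Nc1ccc(S(F)(F)(F)(F)F)cc1`) has not yet been measured in this assay and differs from compound 2 by one change (a group of 6 heavy atoms (5 fluorine, 1 sulfur; no ring) in place of a group of 3 heavy atoms (2 carbon, 1 oxygen; no ring), on an aromatic carbon). Acetyl leaves and a group with no common name enters, on an aromatic carbon para to a large group. Going by the values given here, one measured step bears on this place, acetyl in place of methoxy (a 2.7-fold higher number from compound 1 to compound 2 (0.43 log units; beyond the scatter)), modest and beyond the scatter. That step leaves compound 2 on the high side at 12100 nM and does not involve the entering group, so a smaller step toward a lower number is expected. The expected change is small (a 1.7-fold lower number from compound 2 to compound 3 (0.24 log units; within the scatter)). For compound 3 the estimated value is 7000 nM with an expected range from 2500 nM to 20000 nM in this read-out.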

Compound 3, half-maximal inhibitory concentration: 9110 nM
Compound 3: the middle estimate sits 1.3-fold (0.11 log units) below what was measured; the measured number falls inside the stated range.
By their numbers in this assay, from the lowest: compounds 1, 3 and 2 (each within the scatter of the next, the first and the last beyond it).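

In this assay, the group of 5 fluorine and 1 sulfur on this aromatic carbon cannot be told apart from acetyl (a 1.3-fold lower number from compound 2 to compound 3 (0.12 log units; within the scatter)) or from methoxy (a 2.0-fold higher number from compound 1 to compound 3 (0.30 log units; within the scatter)). The earlier pair showed that a change at this position can move the number beyond the scatter, whereas this replacement of acetyl, which takes away its hydrogen-bond acceptor and puts 6 heavy atoms in place of 3 heavy atoms, does not. Nothing available explains why the numbers fall as they do.

On these data alone, whether an amine, a carboxylic acid or a single fluorine on this carbon would separate clearly from these three compounds remains open. As far as these compounds go, it is also open whether any group here can give a number well below that of compound 1, since all three values lie close together.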